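This account rests on a few compounds, and the source may have more. Where it says the series, first, only, none or still open, it means among the compounds named here.

Measured compounds:

Compound 1, with the structure `Cn1c2c(c3ccccc3c1=O)CCOc1ccccc1-2`: in a functional assay on HL-60 cells (Homo sapiens) for cytotoxicity, read by sulforhodamine B assay (on this read-out lower numbers stand for stronger inhibition and higher numbers for weaker inhibition), compound 1 gives 37600 nM.
Compound 2, with the structure `Cc1ccc2c3c(n(C)c(=O)c2c1)-c1ccccc1OCC3`: in this assay compound 2 gives 14100 nM.
Compound 3, with the structure `COCOc1ccccc1-c1cc2ccccc2c(=O)n1C`: in this assay compound 3 gives 59500 nM.

Among the measured compounds shown here, compounds 1 and 2 share one core, and the only change between them is methyl in place of hydrogen on an aromatic carbon. That change is measured: a 2.7-fold lower number from compound 1 to compound 2 (0.43 log units; beyond the scatter). Compound 3 is built on a different core; how the two cores differ is not broken down here. For the measured compounds named here, of the three numbers the one for compound 3 is the highest, but its gap to compound 1 lies within the usual scatter, while its gap to compound 2 lies beyond it.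

Compound 4, with the structure `COCOc1ccccc1-c1cc2cc(C)ccc2c(=O)n1C`, has not yet been measured in this assay. It arises from compound 3 by methyl in place of hydrogen on an aromatic carbon. Going by the values given here, this is the same kind of change as the one from compound 1 to compound 2, though the ring that carries the methyl sits in a fused system of two rings in compound 4 and of four rings in compound 2. Because the earlier step was a 2.7-fold lower number from compound 1 to compound 2 (0.43 log units; beyond the scatter), a step of similar direction is expected here, and the estimate for it is a 2.0-fold lower number from compound 3 to compound 4 (0.30 log units; within the scatter). On that basis compound 4 is expected to give about 30000 nM, most likely between 12000 nM and 70000 nM.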

Compound 4, half-maximal inhibitory concentration: 14300 nM
For compound 4 the middle estimate is 2.1-fold (0.32 log units) above the measured one, within the range that was stated.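

In this assay, putting a methyl on the aromatic carbon of the two-ring fused system gives a 4.2-fold lower number from compound 3 to compound 4 (0.62 log units; beyond the scatter), so the number falls on this core as well. The same change therefore lowers the number on both cores, and the two steps are close enough in size that they cannot be told apart: the same change on two cores in this assay, a 2.7-fold lower number (0.43 log units; beyond the scatter) from compound 1 to compound 2 and a 4.2-fold lower number (0.62 log units; beyond the scatter) from compound 3 to compound 4, 1.6-fold (0.19 log units) apart, within the scatter of two such steps

For these two pairs, then, the step seen on one core was a fair guide to the step on the other, in direction and roughly in size, even though the methyl-bearing ring sits in a fused system of two rings in compound 4 and of four rings in compound 2. It does not show that the same step would appear on a third core, since two pairs are too few to establish a rule, and it does not explain why the number falls in either pair.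

The compounds shown leave open whether a longer chain such as ethyl, or a different group such as a chlorine atom, a methoxy group or an amine, on that same carbon would lower the number further, leave it unchanged or raise it. They also leave open whether a methyl on another carbon of the same ring would give a similar step.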